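The source may report more compounds than this note shows. Statements on the series, on what has been measured and on what is new or still open speak of the compounds shown alone.

Measured so far in an assay on CHO cells for displacement of a labelled ligand from adenosine receptor A1 (Homo sapiens), tested at 10 uM; a higher number here means more inhibition at the concentration tested (going by the name of the read-out), a lower number less inhibition:
compound 1, `COc1ccccc1CNC(=O)Nc1nn(-c2ccccc2)c(=O)c2ccccc12`: 28%
compound 2, `CC(=O)Nc1nn(-c2ccccc2)c(=O)c2ccccc12`: 52%
compound 3, `COc1ccc(NC(=O)Nc2nn(-c3ccccc3)c(=O)c3ccccc23)c(OC)c1`: 29%

Compound 3 stands second of the three numbers in this assay; compound 1 lies nearest, within the scatter, and compound 2 lies furthest, beyond it. Compound 4, `COc1ccc(NC(=O)Nc2nn(-c3ccccc3)c(=O)c3ccccc23)cc1`, is not yet measured. The change from compound 3 to compound 4 is hydrogen in place of methoxy on an aromatic carbon, a removal of one methoxy group from the aromatic ring on the urea nitrogen. Of the measured steps, a number 1 percentage points higher from compound 1 to compound 3 (within the scatter) concerns the same ring position and is the only one that bears on it; a number 24 percentage points higher from compound 1 to compound 2 (beyond the scatter) alters the carbonyl substituent and is not comparable. A change in this assay of no more than the scatter is therefore expected, as a number 1 percentage points higher from compound 3 to compound 4 (within the scatter). Compound 4 is expected to give 30%, between 15% and 47%.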

Compound 4, a percentage reported as inhibition, at one concentration (the size of the read-out at that concentration, not a potency): 4%
Compound 4: middle estimate off by 26 percentage points, on the high side; measured number outside the range, below it.
By their numbers in this assay, from the lowest: compound 4; then compounds 1 and 3 (each within the scatter of the next); then compound 2.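

In this assay, the methoxy ortho to a large group is not silent on the aryl urea: a number 25 percentage points lower from compound 3 to compound 4 (beyond the scatter). Compound 4, with its 4-methoxyphenyl, also separates from both other compounds, with a number 24 percentage points lower from compound 1 to compound 4 (beyond the scatter) and a number 48 percentage points lower from compound 2 to compound 4 (beyond the scatter), and is the lowest of the four. Nothing at hand accounts for this drop.

From the compounds shown here alone, whether the methoxy itself matters, or any group at that place would do, stays open; a hydroxyl, a fluorine or an amine there would separate the two. Going by these compounds, the role of the remaining methoxy in compound 4 also stays open.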